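The compounds below may be only part of what the source reports. "The series", "measured", "known", "first", "only" and "open" are said of these compounds alone.

Working notes on a short series sharing one core, read in a functional assay on MCF7 cells (Homo sapiens) for cytotoxicity, read by MTT assay, with a stated time of 96 h; on this read-out higher numbers stand for weaker inhibition and lower numbers for stronger inhibition. Compound 1 (`COc1cc(C(=O)c2cn(-c3ccccc3)cc2-c2cccc([N+](=O)[O-])c2)cc(OC)c1OC`) gives 50 nM, and compound 2 (`COc1cc(C(=O)c2cn(-c3cccc(C)c3)cc2-c2cccc([N+](=O)[O-])c2)cc(OC)c1OC`) gives 880 nM. Going by the values given here, the only measured single-site step is an 18-fold higher number from compound 1 to compound 2 (1.25 log units; beyond the scatter), with methyl in place of hydrogen on an aromatic carbon. Compound 3 (`COc1cc(C(=O)c2cn(-c3ccc(F)cc3)cc2-c2ccccc2Cl)cc(OC)c1OC`) gives 83 nM, which lies within the scatter of compound 1 and well under compound 2.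

Compound 4 (`COc1cc(C(=O)c2cn(-c3ccc(F)cc3)cc2-c2cccc([N+](=O)[O-])c2)cc(OC)c1OC`) is still unmeasured. Its difference from compound 3 is 3-nitrophenyl in place of 2-chlorophenyl on an aromatic carbon.

Among the compounds with values here, no measured step swaps the group at this place. Within the data shown here, the one step available, at an 18-fold higher number from compound 1 to compound 2 (1.25 log units; beyond the scatter), lies elsewhere on the molecule, so it gives no direction here and serves only as a warning that one change can move this series a long way. Compound 1 carries the incoming 3-nitrophenyl and gives 50 nM, while compound 2 carries it too and goes against any simple reading at 880 nM. No shift beyond the scatter is therefore expected in this assay, and no direction is favoured. The expected step is a 1.2-fold lower number from compound 3 to compound 4 (0.07 log units; within the scatter). The estimate for compound 4 is 70 nM, with an expected range of 25 nM to 300 nM.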

Compound 4, half-maximal inhibitory concentration: 440 nM
Beside the measured number, compound 4's estimate is 6.3-fold (0.80 log units) below it; measured number outside the range, above it.
By their numbers in this assay, from the lowest: compounds 1 and 3 (each within the scatter of the next); then compounds 4 and 2 (each within the scatter of the next).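

In this assay, the group at this place on the five-membered ring now has a measured effect: with 4-fluorophenyl held on the ring nitrogen, 3-nitrophenyl in place of 2-chlorophenyl gives a 5.3-fold higher number from compound 3 to compound 4 (0.72 log units; beyond the scatter), a step beyond the scatter. With 3-nitrophenyl held, the aryl group on the ring nitrogen also matters, as fluoro in place of hydrogen gives an 8.8-fold higher number from compound 1 to compound 4 (0.94 log units; beyond the scatter), so among compounds 1, 2 and 4 both substituted aryl groups give higher numbers than plain phenyl, while 4-fluorophenyl in place of 3-methylphenyl gives a 2.0-fold lower number from compound 2 to compound 4 (0.30 log units; within the scatter), which stays within the scatter and does not separate those two groups. The series holds no measurement that bears on the origin of these steps.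

2-Chlorophenyl appears here only with 4-fluorophenyl on the ring nitrogen, so its size of effect alongside plain phenyl, where 3-nitrophenyl gives the low number of compound 1, remains open. As far as these compounds go, it is also open whether the step follows the nitro group itself or the place of the substituent on the phenyl ring, which a 3-chlorophenyl group or an amine in place of the nitro group would help to separate.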